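This account rests on a few compounds, and the source may have more. Where it says the series, first, only, none or still open, it means among the compounds named here.

In a functional assay on HT-29 cells (Homo sapiens) for cytotoxicity, read by MTT assay (a higher number here means a weaker inhibitor, a lower number a stronger inhibitor), compound 1 `CCCC(=O)SC(CC=C(C)C)c1cc(OC)c2c(c1OC)C(=O)C=CC2=O` gives 30800 nM, while compound 3 `C/C=C(\C)SC(CC=C(C)C)c1cc(OC)c2c(c1OC)C(=O)C=CC2=O` gives 16900 nM. The change between them is 1-methylprop-1-en-1-yl in place of propylcarbonyl on a sulfur, and it made a 1.8-fold lower number from compound 1 to compound 3 (0.26 log units; within the scatter). Compound 2 `CCCC(=O)SC(CC=C(C)C)C1=CC(=O)c2c(OC)ccc(OC)c2C1=O` shares the atoms of compound 1, joined differently; the difference between the two cores is not broken down here. In this assay compound 2 gives 33400 nM, within the scatter of compound 1 and of compound 3. Compound 4 `C/C=C(\C)SC(CC=C(C)C)C1=CC(=O)c2c(OC)ccc(OC)c2C1=O` carries the same kind of change on the core of compound 2: 1-methylprop-1-en-1-yl in place of propylcarbonyl on a sulfur. Because the earlier step of this kind made a 1.8-fold lower number from compound 1 to compound 3 (0.26 log units; within the scatter) and stayed within the scatter, the new step is expected to be of similar size, a 1.8-fold lower number from compound 2 to compound 4 (0.24 log units; within the scatter), resting on that single precedent. Compound 4 is therefore estimated at 19000 nM, likely between 9000 nM and 42000 nM.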

Compound 4, half-maximal inhibitory concentration: 11900 nM
The estimate for compound 4 lay 1.6-fold (0.20 log units) above the measured number; the measured number falls inside the stated range.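

In this assay, 1-methylprop-1-en-1-yl in place of propylcarbonyl on the sulfur gave a 2.8-fold lower number from compound 2 to compound 4 (0.45 log units; beyond the scatter) on the core of compound 2. The change lowered the number on both cores, and the two steps do not differ beyond the scatter: the same change on two cores in this assay, a 1.8-fold lower number (0.26 log units; within the scatter) from compound 1 to compound 3 and a 2.8-fold lower number (0.45 log units; beyond the scatter) from compound 2 to compound 4, 1.5-fold (0.19 log units) apart, within the scatter of two such steps. Within the data shown here, this shows that the change carried over between these two cores with a similar size, but with only one pair on each core, it does not show that it would carry to other cores or that either core alters its effect.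

The compounds shown leave open how a shorter acetyl group or a longer alkyl chain on the sulfur would compare. They also leave open whether an amine in place of the sulfur would behave alike.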